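Indane Ether in Place of Nitrile on the Shared Core

The source may hold more compounds than are shown below. What is called first, only, known or untested is meant among the compounds shown, and "the series" means these compounds.

Three members of this series have been measured in an assay on HeLa cells for inhibition of Indoleamine 2,3-dioxygenase 1 (Homo sapiens), with a stated time of 20 h; on this read-out higher numbers stand for weaker inhibition and lower numbers for stronger inhibition. Compound 1 `CCc1ccccc1Oc1ccc(-c2ccc(OC)c(C(=O)O)c2)cc1NC(=O)Nc1ccc(C)cc1` gives 540 nM in this assay. Compound 2 `COc1ccc(-c2ccc(Oc3ccccc3Cl)c(NC(=O)Nc3ccc(C)cc3)c2)cc1C(=O)O` gives 830 nM, and compound 3 `COc1ccc(-c2ccc(Oc3ccccc3C#N)c(NC(=O)Nc3ccc(C)cc3)c2)cc1C(=O)O` gives 6000 nM. Compound 3 therefore has the highest number of the three, separated from compound 2 by a 7.2-fold higher number from compound 2 to compound 3 (0.86 log units; beyond the scatter) and from compound 1 by an 11-fold higher number from compound 1 to compound 3 (1.05 log units; beyond the scatter). The step of a 1.5-fold higher number from compound 1 to compound 2 (0.19 log units; within the scatter) shows that an ethyl and a chloro on that aromatic carbon give numbers that cannot be told apart.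

Compound 4 `COc1ccc(-c2ccc(Oc3cccc4c3CCC4)c(NC(=O)Nc3ccc(C)cc3)c2)cc1C(=O)O` is the next member. It differs from compound 3 in one place: 2,3-dihydro-1H-inden-4-yl in place of 2-cyanophenyl on an oxygen on an aromatic ring. For the measured compounds named here, the steps that bear on this change are an 11-fold higher number from compound 1 to compound 3 (1.05 log units; beyond the scatter) and a 7.2-fold higher number from compound 2 to compound 3 (0.86 log units; beyond the scatter), both of which show that removing the cyano from this position, whatever takes its place among the two groups tried, lowers the number considerably. The 2,3-dihydro-1H-inden-4-yl group carries no hydrogen-bond acceptor, like the ethyl and chloro groups of compound 1 and compound 2. The expectation is therefore a step of a 10-fold lower number from compound 3 to compound 4 (1.00 log units; beyond the scatter) in this assay, bringing compound 4 back toward the range of compound 1 and compound 2. The estimate for compound 4 is 600 nM, expected to fall between 250 nM and 1500 nM.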

Compound 4, half-maximal inhibitory concentration: 280 nM
Estimate against measurement, compound 4: 2.1-fold (0.33 log units) above; low and high end bracket the measured number.
By their numbers in this assay, from the lowest: compounds 4, 1 and 2 (each within the scatter of the next, the first and the last beyond it); then compound 3.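

In this assay, the replacement of 2-cyanophenyl by 2,3-dihydro-1H-inden-4-yl on this oxygen gives a 21-fold lower number from compound 3 to compound 4 (1.33 log units; beyond the scatter), which shows that the position accepts a group with a second ring, a five-membered non-aromatic ring of carbon only, and not just a single phenyl ring carrying ethyl or chloro. For the compounds shown here, the new group also separates two groups that the earlier compounds could not: a 3.0-fold lower number from compound 2 to compound 4 (0.47 log units; beyond the scatter) lies beyond the scatter, whereas a 1.9-fold lower number from compound 1 to compound 4 (0.29 log units; within the scatter) lies within it, so the 2,3-dihydro-1H-inden-4-yl and 2-ethylphenyl groups cannot be told apart in this assay, although the 2-chlorophenyl group can be told apart from the former but not from the latter. Nothing available here accounts for these differences between the groups on this oxygen.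

The compounds shown leave open whether the high number of compound 3 belongs to the nitrile specifically, or would also appear with a methoxy group or an amine in its place on that ring. They also leave open whether a fused six-membered carbon ring in place of the five-membered one would give a number like that of compound 4.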